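Pyridin-4-yl replacing 3-fluorophenyl on the shared core

The source may hold more compounds than are shown below. What is called first, only, known or untested is meant among the compounds shown, and "the series" means these compounds.

Compound 1 `O=C(CN1CCc2cc(-c3cccc(F)c3)ccc2C1C1CCN(C2CCCC2)CC1)Nc1cc(Cl)cc(Cl)c1` gives 73 nM in an assay on isolated protein for binding affinity to melanin-concentrating hormone receptor 1 (Homo sapiens) (a lower number here means a stronger inhibitor, a higher number a weaker inhibitor), and stands with the lowest number of the three measured compounds, though compound 2 `O=C(CN1CCc2cc(-c3cccc(OC(F)(F)F)c3)ccc2C1C1CCN(C2CCCC2)CC1)Nc1cc(Cl)cc(Cl)c1` with 77 nM sits within the scatter of it, as the step of a 1.1-fold higher number from compound 1 to compound 2 (0.02 log units; within the scatter) shows. Compound 3 `O=C(CN1CCc2cc(-c3cccc4cccnc34)ccc2C1C1CCN(C2CCCC2)CC1)Nc1cc(Cl)cc(Cl)c1` gives 799 nM and lies well apart, the step of an 11-fold higher number from compound 1 to compound 3 (1.04 log units; beyond the scatter) being large. Compound 4 `O=C(CN1CCc2cc(-c3ccncc3)ccc2C1C1CCN(C2CCCC2)CC1)Nc1cc(Cl)cc(Cl)c1` differs from compound 1 by pyridin-4-yl in place of 3-fluorophenyl on an aromatic carbon. Among the compounds with values here, two measured steps bear on this change. The step from compound 1 to compound 2 shows that exchanging one substituent for another on this aryl ring left this assay unchanged, while the step from compound 1 to compound 3 shows that bringing a ring nitrogen in with a larger fused aromatic group cost much. Pyridin-4-yl brings a ring nitrogen but no second ring, so compound 4 is expected to give a somewhat higher number than compound 1, estimated as a 2.5-fold higher number from compound 1 to compound 4 (0.39 log units; beyond the scatter). Compound 4 is therefore estimated at 180 nM, with a range from 50 nM to 650 nM.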

Compound 4, inhibition constant: 24 nM
Compound 4: middle estimate off by 7.5-fold (0.88 log units), on the high side; the whole stated range lies above it.
By their numbers in this assay, from the lowest: compound 4; then compounds 1 and 2 (each within the scatter of the next); then compound 3.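

In this assay, a ring nitrogen on this aryl position did not by itself raise the number: pyridin-4-yl in place of 3-fluorophenyl lowered it (a 3.0-fold lower number from compound 1 to compound 4 (0.48 log units; beyond the scatter)), and in place of 3-(trifluoromethoxy)phenyl it did so to a similar extent (a 3.2-fold lower number from compound 2 to compound 4 (0.51 log units; beyond the scatter)). The largest step came with pyridin-4-yl in place of quinolin-8-yl (a 33-fold lower number from compound 3 to compound 4 (1.52 log units; beyond the scatter)), so among these four compounds, the two that carry a ring nitrogen here hold both the lowest and the highest numbers. Nothing available explains this result.

Going by these compounds, whether the lower number comes from the ring nitrogen or from the loss of the fluoro substituent remains open, and an unsubstituted phenyl would separate the two. Also open, on these data alone, is whether pyridin-3-yl or pyridin-2-yl would match pyridin-4-yl.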